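The source may hold more compounds than are shown below. What is called first, only, known or untested is meant among the compounds shown, and "the series" means these compounds.

Compound 3 `CCC(CC)(c1ccc(OCCCO)c(C)c1)c1ccc(OCC(O)C(C)(C)C)c(OCC(O)C(C)(C)C)c1` gives 76% in an assay on cells for binding affinity to vitamin D3 receptor (Homo sapiens), read by fluorescence, tested at 1 uM (a higher number here means more inhibition at the concentration tested (going by the name of the read-out), a lower number less inhibition), and stands second highest of the three numbers measured; compound 2 `CCC(CC)(c1ccc(OCC(O)CO)c(C)c1)c1ccc(OCC(O)C(C)(C)C)c(OCC(O)C(C)(C)C)c1` gives 78%, and compound 1 `CCC(CC)(c1ccc(OS(=O)(=O)c2ccc(C)cc2)c(C)c1)c1ccc(OCC(O)C(C)(C)C)c(OCC(O)C(C)(C)C)c1` gives 43%. The step of a number 2 percentage points lower from compound 2 to compound 3 (within the scatter) stays within the scatter, whereas a number 35 percentage points higher from compound 1 to compound 2 (beyond the scatter) and a number 33 percentage points higher from compound 1 to compound 3 (beyond the scatter) are both large. Compound 4 `CCC(CC)(c1ccc(OCCCCCO)c(C)c1)c1ccc(OCC(O)C(C)(C)C)c(OCC(O)C(C)(C)C)c1` differs from compound 3 by 2-hydroxyethyl in place of hydroxy on a saturated chain carbon, three bonds along the chain from an oxygen on an aromatic ring. For the measured compounds named here, the only measured step touching this chain, a number 2 percentage points lower from compound 2 to compound 3 (within the scatter), lay within the scatter, so a change at this chain end has so far moved the number little; the large steps from compound 1 concern a different group and do not bear on it. A step of no more than the scatter is therefore expected, a number 2 percentage points lower from compound 3 to compound 4 (within the scatter). Compound 4 is estimated at 74%, range 58% to 88%.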

Compound 4, a percentage reported as inhibition, at one concentration (the size of the read-out at that concentration, not a potency): 67%
For compound 4 the middle estimate is 7 percentage points above the measured one; low and high end bracket the measured number.
By their numbers in this assay, from the lowest: compound 1; then compounds 4, 3 and 2 (each within the scatter of the next, the first and the last beyond it).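

In this assay, 5-hydroxypentyl in place of 3-hydroxypropyl gives a number 9 percentage points lower from compound 3 to compound 4 (within the scatter) and so leaves the reading within the scatter at this chain length. Against the 2,3-dihydroxypropyl chain, the 5-hydroxypentyl chain gives a number 11 percentage points lower from compound 2 to compound 4 (beyond the scatter), the first step beyond the scatter among these hydroxy-ended chains. Compared with the (4-methylphenyl)sulfonyl group, it gives a number 24 percentage points higher from compound 1 to compound 4 (beyond the scatter) and so keeps most of the large step seen with the shorter chains. No available evidence explains these steps. Open, as far as these compounds go, is whether an amine or a carboxylic acid at this chain end, or a chain longer than 5-hydroxypentyl, would hold the reading.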